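From Propoxycarbonyl to Propylcarbonyl: What to Expect

This account rests on a few compounds, and the source may have more. Where it says the series, first, only, none or still open, it means among the compounds named here.

Measured so far:
compound 1, `CCOC(=O)C1=CCCCC1S(=O)(=O)Cc1ccc(Cl)c(Cl)c1`: 53 nM
compound 2, `CCOC(=O)C1=CCCCC1S(=O)(=O)Cc1ccc(Cl)cc1Cl`: 60 nM
compound 3, `CCCOC(=O)C1=CCCCC1S(=O)(=O)Cc1ccc(F)cc1Cl`: 14 nM

All three were tested in a functional assay on RAW264.7 cells (Mus musculus), read by fluorescence; a lower number here means a stronger inhibitor, a higher number a weaker inhibitor. Compound 3 gives the lowest number of the three, and its gaps to compound 1 and to compound 2 both lie beyond the usual scatter, so compound 3 is the strongest inhibitor in this set. Compound 1 and compound 2 sit within the scatter of each other, so nothing separates them.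

Compound 4, `CCCC(=O)C1=CCCCC1S(=O)(=O)Cc1ccc(F)cc1Cl`, is not yet measured. It differs from compound 3 in one place: propyl in place of propoxy on a carbonyl carbon. Among the compounds with values here, no pair among the measured compounds shows this kind of change, so there is no measured step to lean on. The change keeps the chain length and removes one oxygen. Compound 4 is expected to give a somewhat higher number than compound 3, a step from a 2.5-fold higher number from compound 3 to compound 4 (0.40 log units; beyond the scatter) that may or may not exceed the scatter. For compound 4 the estimate is 35 nM, within a range from 9 nM to 140 nM.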

Compound 4, half-maximal inhibitory concentration: 11 nM
Beside the measured number, compound 4's estimate is 3.2-fold (0.50 log units) above it, within the range that was stated.
By their numbers in this assay, from the lowest: compounds 4 and 3 (each within the scatter of the next); then compounds 1 and 2 (each within the scatter of the next).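

In this assay, putting propyl in place of propoxy on this carbonyl carbon gives a 1.3-fold lower number from compound 3 to compound 4 (0.10 log units; within the scatter), so the two compounds cannot be told apart. Within the data shown here, this is the first one-place change measured in the set, and it shows that, for this pair, the oxygen lost with the propoxy group and its one hydrogen-bond acceptor are not needed to keep the number at the level of compound 3. No further measurement bears on why the two numbers match.

From the compounds shown here alone, whether a longer chain such as butyl, or an amine on the same carbonyl carbon, would keep the number in this assay remains open. So does whether the same change would read alike on the core of compound 1.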